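Fluoro to Methoxy on the Carbonyl-Bound Phenyl

The source may hold more compounds than are shown below. What is called first, only, known or untested is meant among the compounds shown, and "the series" means these compounds.

Compound 1, `CCC(=O)N(C)c1ccc2[nH]c(-c3n[nH]c4ccccc34)cc2n1`: in a functional assay on HCT-116 cells (Homo sapiens) for antiproliferative activity, read by MTT assay, with a stated time of 72 h (a higher number here means a weaker inhibitor, a lower number a stronger inhibitor), compound 1 gives 10800 nM.
Compound 2, `CN(C(=O)C(C)(C)C)c1ccc2[nH]c(-c3n[nH]c4ccccc34)cc2n1`: in this assay compound 2 gives 18000 nM.
Compound 3, `CN(C(=O)c1ccc(F)cc1)c1ccc2[nH]c(-c3n[nH]c4ccccc34)cc2n1`: in this assay compound 3 gives 9270 nM.

Compound 3 has the lowest of the three numbers, but the steps leading to it, a 1.2-fold lower number from compound 1 to compound 3 (0.07 log units; within the scatter) and a 1.9-fold lower number from compound 2 to compound 3 (0.29 log units; within the scatter), both sit within the scatter, so the three compounds cannot be told apart on these data. Compound 4 is `COc1ccc(C(=O)N(C)c2ccc3[nH]c(-c4n[nH]c5ccccc45)cc3n2)cc1`. The change from compound 3 is methoxy in place of fluoro on an aromatic carbon.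

The measured steps all exchange the whole group on the carbonyl carbon: a 1.7-fold higher number from compound 1 to compound 2 (0.22 log units; within the scatter), a 1.2-fold lower number from compound 1 to compound 3 (0.07 log units; within the scatter) and a 1.9-fold lower number from compound 2 to compound 3 (0.29 log units; within the scatter). Each stayed within the scatter. For the measured compounds named here, none of them alters a substituent on the phenyl that is already present, so the fluoro-to-methoxy exchange has no direct precedent here; the nearest evidence is that varying the carbonyl substituent broadly left the numbers where they were.

The step of a 1.0-fold lower number from compound 3 to compound 4 (0.01 log units; within the scatter) is therefore expected to be small, with no direction beyond the scatter. Compound 4 is estimated at 9000 nM, in the range 4000 nM to 20000 nM.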

Compound 4, half-maximal inhibitory concentration: 29500 nM
For compound 4 the middle estimate is 3.3-fold (0.52 log units) below the measured one; the measured number lies above the stated range.
By their numbers in this assay, from the lowest: compounds 3, 1, 2 and 4 (each within the scatter of the next, the first and the last beyond it).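

In this assay, a single substituent on the phenyl ring shifts the number more clearly than the earlier exchanges of the whole group on the carbonyl carbon among compounds 1, 2 and 3: a 3.2-fold higher number from compound 3 to compound 4 (0.50 log units; beyond the scatter) marks compound 4 as a modestly weaker inhibitor than its fluoro partner. The comparison with the other carbonyl groups is mixed, since 4-methoxyphenyl in place of ethyl gives a 2.7-fold higher number from compound 1 to compound 4 (0.44 log units; beyond the scatter), while 4-methoxyphenyl in place of tert-butyl gives a 1.6-fold higher number from compound 2 to compound 4 (0.21 log units; within the scatter), leaving compound 4 and compound 2 indistinguishable. No measurement presented here bears on the reason for the methoxy step.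

From the compounds shown here alone, how a hydroxyl, an amino group or a plain hydrogen at this place on the phenyl would compare remains open. So does whether a longer chain such as ethoxy would follow methoxy or return towards fluoro.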